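This account rests on a few compounds, and the source may have more. Where it says the series, first, only, none or still open, it means among the compounds named here.

Compound 3 `COc1cc2c(c(O)c1C(=O)/C=C/c1ccc(OC(=O)c3ccc(OC(F)(F)F)cc3)cc1)CCC(C)(C)O2` belongs to a small set built on a shared core. In an assay on HEK293T cells for inhibition of nuclear factor NF-kappa-B complex (Homo sapiens), read by a luciferase reporter (a lower number here means a stronger inhibitor, a higher number a weaker inhibitor), compound 3 gives > 30000 nM, which is a limit of the assay rather than a number. Compound 1 `COc1cc2c(c(O)c1C(=O)/C=C/c1ccc(OC(=O)c3cccc(Cl)c3)cc1)CCC(C)(C)O2` and compound 2 `COc1cc2c(c(O)c1C(=O)/C=C/c1ccc(OC(=O)c3ccc(Cl)nc3)cc1)CCC(C)(C)O2` carry other groups on the same carbonyl carbon. In this assay compound 1 gives > 30000 nM, again a limit. In this assay compound 2 gives > 30000 nM, also a limit. As a result the steps a step that the two limits leave unreadable from compound 1 to compound 2, a step that the two limits leave unreadable from compound 1 to compound 3 and a step that the two limits leave unreadable from compound 2 to compound 3 cannot be sized; all three readings sit at the limit of > 30000 nM in this assay, at which 3 of the 3 values shown sit.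

Compound 4 `C=CC(=O)Oc1ccc(/C=C/C(=O)c2c(OC)cc3c(c2O)CCC(C)(C)O3)cc1` has not yet been tested. It differs from compound 3 by vinyl in place of 4-(trifluoromethoxy)phenyl on a carbonyl carbon. For the measured compounds named here, no measured step bears readably on this change; every exchange at this carbonyl carbon so far left the reading at the limit, so nothing here points toward a gain or a loss beyond the scatter. Compound 4 is therefore expected to remain near that limit, the estimated step being a number no higher from compound 3 to compound 4 (the limit leaves the size open). For compound 4 the estimate is 30000 nM, with a range from 5000 nM to 100000 nM.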

Compound 4, half-maximal inhibitory concentration: 8990 nM
Beside the measured number, compound 4's estimate is 3.3-fold (0.52 log units) above it, within the range that was stated.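

Vinyl is the first group on this carbonyl carbon to bring a reading off the limit, which shows that this position can change the result in this assay: the exchange brings an at least 3.3-fold lower number from compound 3 to compound 4 (0.52 log units; beyond the scatter). Replacing either of the other two groups with vinyl brings an at least 3.3-fold lower number from compound 2 to compound 4 (0.52 log units; beyond the scatter) and an at least 3.3-fold lower number from compound 1 to compound 4 (0.52 log units; beyond the scatter). These sizes are only minimums, and the steps among compound 1, compound 2 and compound 3 still cannot be read, as all three remain held at the same limit: the limit of > 30000 nM in this assay, at which 3 of the 4 values shown sit.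

The compounds shown do not tell whether the double bond of vinyl matters, or only the loss of the larger ring-bearing group. An ethyl group, the saturated counterpart of vinyl, or a small ring-free chain such as propyl would help separate those two readings.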